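The source may report more compounds than this note shows. Statements on the series, on what has been measured and on what is new or still open speak of the compounds shown alone.

Compound 1, `Cc1ccc(-n2cc(CNC(=O)c3cccc4c3cnn4C(C)C)nn2)cc1C`, in a functional assay on HepG2 cells (Homo sapiens) for inhibition, read by MTT assay, with a stated time of 72 h (a lower number here means a stronger inhibitor, a higher number a weaker inhibitor), gives only the limit > 40000 nM.
Compound 2, `CC(C)n1ncc2c(C(=O)NCc3cn(-c4cccc(F)c4)nn3)cccc21`, in this assay gives only the limit > 40000 nM.
Compound 3, `Cc1cccc(-n2cc(CNC(=O)c3cccc4c3cnn4C(C)C)nn2)c1`, in this assay gives only the limit > 40000 nM.

Compound 3 stands where the other two stand: at the limit of > 40000 nM in this assay, at which 3 of the 3 values shown sit, so no number for it is known, only that it is a weak inhibitor by this measure. Every step between the three measured compounds, a step that the two limits leave unreadable from compound 1 to compound 2, a step that the two limits leave unreadable from compound 1 to compound 3 and a step that the two limits leave unreadable from compound 2 to compound 3, is unreadable, since each joins two limits. All three steps swap the group on the same aromatic nitrogen of the shared core, and none moved a compound off the limit.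

Compound 4, `COc1ccc(-n2cc(CNC(=O)c3cccc4c3cnn4C(C)C)nn2)cc1`, differs from compound 3 by 4-methoxyphenyl in place of 3-methylphenyl on an aromatic nitrogen. This is again a change of the group on that aromatic nitrogen, so the three unreadable steps are the ones that bear on it. For the measured compounds named here, they give no size and no direction; they show only that such swaps have so far left every compound at the limit. Compound 4 is therefore expected to be reported as a limit again, with no step beyond the scatter that can be read. Compound 4 is estimated at 50000 nM, within 20000 nM to 120000 nM. The step this estimate implies, a step that the limit leaves unreadable from compound 3 to compound 4, is expected to stay unreadable as well.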

Compound 4, half-maximal inhibitory concentration: > 40000 nM
Compound 4: only a limit was reported (the forecaster's own chance of this, stated with the estimate: 85%); the middle value does not contradict the limit.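

Compound 4 also gives only a limit in this assay and not a number, so its steps from compound 1, compound 2 and compound 3 cannot be read, and all four compounds stay together: the limit of > 40000 nM in this assay, at which 4 of the 4 values shown sit. The compounds shown leave open how strong each really is, and whether any group on that aromatic nitrogen would give a measurable number.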